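The compounds below may be only part of what the source reports. "The series", "measured", "known", "first", "only" and "open" are said of these compounds alone.

Working notes on the benzylthio series. In an assay on isolated protein for inhibition of Amine oxidase [flavin-containing] B (Homo sapiens) (on this read-out higher numbers stand for weaker inhibition and lower numbers for stronger inhibition), compound 3 `C#CCNC1CCc2c(SCc3ccc(C)cc3)cccc21` gives 1560 nM. Compound 2 `C#CCNC1CCc2c(SCc3ccc(Br)cc3)cccc21` gives 1310 nM in this assay, and the step of a 1.2-fold higher number from compound 2 to compound 3 (0.08 log units; within the scatter) places the two together. Compound 1 `C#CCNC1CCc2c(SCc3cccc(C)c3)cccc21` returns only a limit in this assay, > 100000 nM. Of the two numbers shown, compound 3 holds the higher, with compound 2 nearest; the remaining value is a limit (the limit of > 100000 nM in this assay, at which 1 of the 3 values shown sits).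

Compound 4 `C#CCNC1CCc2c(SCc3cccc(Br)c3)cccc21` differs from compound 3 by 3-bromophenyl in place of 4-methylphenyl on a saturated chain carbon bound to a sulfur. For the measured compounds named here, two measured steps bear on this change. The exchange of 3-methylphenyl for 4-methylphenyl produced an at least 64-fold lower number from compound 1 to compound 3 (1.80 log units; beyond the scatter), so the 3-substituted arm is strongly disfavoured here. The exchange of bromo for methyl on the aromatic carbon produced a 1.2-fold higher number from compound 2 to compound 3 (0.08 log units; within the scatter), so bromo and methyl behave alike at that site. Compound 4 combines the 3-substitution pattern of compound 1 with a group shown to be interchangeable with methyl, so a large rise in number is expected, a 38-fold higher number from compound 3 to compound 4 (1.59 log units; beyond the scatter). The estimate for compound 4 is 60000 nM, with a range of 10000 nM to 300000 nM, and a real chance that this assay returns only a limit for compound 4.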

Compound 4, half-maximal inhibitory concentration: > 100000 nM
Compound 4 gave a limit, no number (the forecaster's own chance of this, stated with the estimate: 50%); middle value at least 1.6-fold (0.22 log units) away from the limit.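

Compound 4 shows that the loss seen with compound 1 does not belong to the methyl group alone, since the 3-bromophenyl arm on this saturated chain carbon bound to a sulfur also leaves only a limit, not a number, in this assay: the limit of > 100000 nM in this assay, at which 2 of the 4 values shown sit. For the compounds shown here, with bromo held constant, the change from the 4-bromophenyl arm gives an at least 76-fold higher number from compound 2 to compound 4 (1.88 log units; beyond the scatter), the first such comparison with the same substituent on both arms, and the exchange for the 4-methylphenyl arm gives an at least 64-fold higher number from compound 3 to compound 4 (1.80 log units; beyond the scatter). The step between compound 1 and compound 4 cannot be read, so bromo and methyl can be told apart on neither side here: they sit within the scatter on the 4-substituted arms, and the two limits hide any difference on the 3-substituted arms.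

From the compounds shown here alone, how far the true values of compound 1 and compound 4 lie past the limit stays open, and so does the size of the drop for either substituent. Also open, going by these compounds, is whether the same split between 3-substituted and 4-substituted arms holds for methoxy, chloro or a carboxylic acid, or how an unsubstituted phenyl compares with both.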